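Chloro on the semicarbazone series: Vero cytotoxicity limit

The source may report more compounds than this note shows. Statements on the series, on what has been measured and on what is new or still open speak of the compounds shown alone.

Compound 1 `CC(=O)c1ccc2[nH]c(-c3ccc(Cl)cc3)nc2c1` gives > 100000 nM in an ADME assay on Vero cells (Chlorocebus sabaeus) for cytotoxicity, read by MTT assay, with a stated time of 96 h; a lower number here means that less compound is tolerated, a higher number that more compound is tolerated (a limit)
Compound 2 `C/C(=N\NC(N)=O)c1ccc2[nH]c(-c3ccccc3)nc2c1` gives > 100000 nM in this assay (a limit)

Compound 2 gives > 100000 nM as a limit and not as a number. For the measured compounds named here, the series so far shows (the limit of > 100000 nM in this assay, at which 2 of the 2 values shown sit), so the measurements offer no graded comparison.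

Compound 3 `C/C(=N\NC(N)=O)c1ccc2[nH]c(-c3ccc(Cl)cc3)nc2c1` departs from compound 2 by a single change, (chloro in place of hydrogen on an aromatic carbon), with chloro in place of hydrogen on an aromatic carbon, para to a large group, so that phenyl becomes 4-chlorophenyl.

Going by the values given here, no measured step isolates this change. Compound 1 also carries 4-chlorophenyl and gives > 100000 nM as a limit. No shift beyond the scatter is therefore expected in this assay, in either direction. The expected change is a number no higher from compound 2 to compound 3 (the limit leaves the size open) on this estimate. For compound 3 the estimated value is 100000 nM, with an expected range from 40000 nM to 150000 nM.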

Compound 3, half-maximal cytotoxic concentration: > 100000 nM
Compound 3 ended at the assay's limit; the forecaster's own chance of this, stated with the estimate: 70%; the middle value sits exactly at the limit.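

No step to compound 3 can be read from compound 1 or compound 2 in this assay, because all three values are limits: the limit of > 100000 nM in this assay, at which 3 of the 3 values shown sit.

The compounds shown leave open how far each value lies past the limit, and whether phenyl to 4-chlorophenyl shifts it at all.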